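Chlorotriazine series: aminotriazine variation at the six-membered core

The compounds below may be only part of what the source reports. "The series", "measured", "known", "first", "only" and "open" are said of these compounds alone.

Measured so far:
Compound 1 `CC[C@@H](C)Nc1nc(Cl)nc(N[C@@H](C)c2ccccc2)n1` — 7410 nM
Compound 2 `CCN(c1nc(Cl)nc(N[C@H](C)c2ccccc2)n1)C(C)C` — 52500 nM
Compound 3 `CNc1nc(Cl)nc(N[C@H](C)c2ccccc2)n1` — 562 nM

In an ADME assay on the whole organism for inhibition, with Echinochloa crus-galli var. formosensis as the target, with a stated time of 4 days (on this read-out lower numbers stand for stronger inhibition and higher numbers for weaker inhibition), compound 1 stands second highest of the three numbers; compound 2 sits higher and compound 3 lower, both beyond the scatter. Compound 4 `CCCN(C)c1nc(Cl)nc(N[C@@H](C)c2ccccc2)n1` is not yet measured. It differs from compound 1 in one place: methyl(propyl)amino in place of (sec-butyl)amino on an aromatic carbon. The entering group carries no hydrogen-bond donor, whereas the leaving group carries one.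

Within the data shown here, one measured step bears on this. From compound 2 to compound 3 the change was a 93-fold lower number from compound 2 to compound 3 (1.97 log units; beyond the scatter), going from a dialkylated amino group to one bearing a hydrogen. The step from compound 1 to compound 4 runs the opposite way, from an amino group with a hydrogen to a dialkylated one, so a higher number is expected. Among the measured compounds shown here, no step is recorded between compound 1 and compound 2, but their two values point the same way, with the dialkylated compound 2 giving the higher number.

Compound 4 is therefore expected to give 25000 nM, with a range of 8000 nM to 80000 nM, an expected step of a 3.4-fold higher number from compound 1 to compound 4 (0.53 log units; beyond the scatter) from compound 1.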

Compound 4, half-maximal inhibitory concentration: 380 nM
Compound 4: the middle estimate sits 66-fold (1.82 log units) above what was measured; the whole stated range lies above it.
By their numbers in this assay, from the lowest: compounds 4 and 3 (each within the scatter of the next); then compound 1; then compound 2.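

In this assay, methyl(propyl)amino in place of (sec-butyl)amino gives a 20-fold lower number from compound 1 to compound 4 (1.29 log units; beyond the scatter), although the two groups hold the same atoms joined differently, so at this position the number depends on how those atoms are joined and not only on which atoms are present. This step removes the hydrogen-bond donor, whereas a 93-fold lower number from compound 2 to compound 3 (1.97 log units; beyond the scatter) adds one, so across these two steps the number falls with either change and the donor count alone does not order the values. No measurement shown here links the size of the new step to any property of the two groups.

The step changes the donor, the branching and the defined stereocentre of the leaving group all at once, and the compounds shown do not separate these; n-butylamino, which keeps the donor without the stereocentre, and the other stereoisomer of (sec-butyl)amino would each bear on that. Going by these compounds, compound 2 and compound 4 differ in more than one place, so how far the outcome depends on the particular dialkylamino group also stays open.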